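The source may hold more compounds than are shown below. What is called first, only, known or untested is meant among the compounds shown, and "the series" means these compounds.

Working notes on the series in a functional assay on P388 cells (Mus musculus); a lower number here means that less compound is needed, a higher number that more compound is needed for the effect.

Compound 2 `Cc1nn(C[C@@H]2CO[C@H](CO)O2)c(=O)[nH]c1=O` gives only a limit of the assay in this assay, > 100000 nM, so its position is known just as a floor of the numbers shown, set by the limit of > 100000 nM in this assay, at which 1 of the 3 values shown sits. Compound 4 `Cc1nn(C[C@@H]2CO[C@@H](CO)O2)c(=O)[nH]c1=O` is not yet measured. The change from compound 2 to compound 4 is the two compounds have the same atoms and bonds and differ only in configuration as drawn: 1 of 2 stereo elements differ; a stereocentre at a saturated ring carbon is drawn S in compound 2 and R in compound 4.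

Among the compounds with values here, one measured step bears on it. Compound 1 `Nc1ncn(C[C@H]2CO[C@H](CO)O2)c(=O)n1` gives 65000 nM in this assay, and compound 3 `Nc1ncn(C[C@H]2CO[C@@H](CO)O2)c(=O)n1` gives 70000 nM; the step of a 1.1-fold higher number from compound 1 to compound 3 (0.03 log units; within the scatter) is within the scatter. That pair is the only one in the set that matches the present change because of the fact that compounds 1 and 3 differ only in the configuration as drawn. On that basis the change of configuration alone is not expected to move the number beyond the scatter in either direction.

Compound 4 is therefore expected to stand where compound 2 stands, most likely again at the limit of the assay, with the estimated step that the limit leaves unreadable from compound 2 to compound 4 and an estimated value of 150000 nM, range 70000 nM to 400000 nM.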

Compound 4, half-maximal effective concentration: > 100000 nM
Compound 4 was reported as a limit; the forecaster's own chance of this, stated with the estimate: 80%; the middle value is on the limit's open side.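

Compound 2 and compound 4 are both reported only as limits in this assay, so no step can be read between them. The compounds shown leave open whether this change of configuration moves the number at all for this pair, and where either compound's actual value lies.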